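The compounds below may be only part of what the source reports. "The series", "measured", "known", "first", "only" and "open" are said of these compounds alone.

In a functional assay on T47D cells (Homo sapiens) for antiproliferative activity, read by MTT assay, with a stated time of 72 h (a higher number here means a weaker inhibitor, a lower number a stronger inhibitor), compound 2 `COc1cc(-c2nccn2CC(C)C)cc(OC)c1OC` gives > 100000 nM, which is a limit and not a number. Compound 1 `CCn1ccnc1-c1cc(OC)c(OC)c(OC)c1` gives > 100000 nM, also a limit. Compound 2 thus stands at the limit of > 100000 nM in this assay, at which 2 of the 3 values shown sit. Among the compounds with values here, the one measured step, a step that the two limits leave unreadable from compound 1 to compound 2, offers no size to carry forward. Compound 4 `COc1cc(-c2nccn2-c2cccc(C)c2)cc(OC)c1OC` has 3-methylphenyl in place of isobutyl on an aromatic nitrogen. The nearest guide is compound 3 `COc1ccc(-n2ccnc2-c2cc(OC)c(OC)c(OC)c2)cc1[N+](=O)[O-]`, which also has a six-membered aromatic ring of carbon only on that nitrogen and gives 10000 nM. On that value, stronger inhibition is expected, though a result at the limit remains possible. The expected change is an at least 5.0-fold lower number from compound 2 to compound 4 (0.69 log units; beyond the scatter). For compound 4 the estimate is 20000 nM, with an expected range of 5000 nM to 100000 nM.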

Compound 4, half-maximal inhibitory concentration: 29300 nM
Compound 4: the middle estimate sits 1.5-fold (0.17 log units) below what was measured; the range from low to high includes it.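

Replacing isobutyl with 3-methylphenyl on the aromatic nitrogen gives an at least 3.4-fold lower number from compound 2 to compound 4 (0.53 log units; beyond the scatter) in this assay, and replacing ethyl gives an at least 3.4-fold lower number from compound 1 to compound 4 (0.53 log units; beyond the scatter). With the core otherwise unchanged, this position can therefore bring a compound off the limit where both alkyl-bearing compounds sit. Both sizes are only minimum sizes, because compound 1 and compound 2 each rest on a limit and not a number: the limit of > 100000 nM in this assay, at which 2 of the 4 values shown sit.

Whether the ring itself or its methyl accounts for the lower number stays open. Also open, on these data alone, is what a plain phenyl, or a phenyl bearing an amine, would give on the same nitrogen.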